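The compounds below may be only part of what the source reports. "The series", "measured", "known", "first", "only" and "open" are said of these compounds alone.

Working notes on the series. In a functional assay on HCT-116 cells (Homo sapiens) for inhibition, read by CCK-8 assay, with a stated time of 72 h, tested at 2 uM (a lower number here means less inhibition of growth, a higher number more inhibition of growth at the concentration tested), compound 1 (`Nc1ccccc1NC(=O)/C=C/c1ccc(CSc2ccc(Cl)cc2)cc1`) gives 5.62%, within the scatter of compound 3 (`Nc1ccccc1NC(=O)c1ccc(CSc2cccc(F)c2)cc1`) at 5.5%, while compound 2 (`CCc1ccc(SCc2ccc(C(=O)Nc3ccccc3N)cc2)cc1`) reads 40.7%. Compound 4 (`Nc1ccccc1NC(=O)/C=C/c1ccc(CSc2ccc(C(F)(F)F)cn2)cc1`) keeps the core of compound 1 and changes one group: 5-(trifluoromethyl)pyridin-2-yl in place of 4-chlorophenyl on a sulfur. Within the data shown here, the only measured step bearing on this change is a number 35.2 percentage points lower from compound 2 to compound 3 (beyond the scatter). It is large and shows that the group on the sulfur can matter, but it was measured on a different core and with different groups. Among the measured compounds shown here, no measured step starts from 4-chlorophenyl, so only a small rise is expected, with the estimated step of a number 6.4 percentage points higher from compound 1 to compound 4 (within the scatter) staying within the scatter. For compound 4 the estimated value is 12%, with an expected range of 2% to 35%.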

Compound 4, percent growth inhibition at one concentration: 4.42%
Compound 4: middle estimate off by 7.6 percentage points, on the high side; low and high end bracket the measured number.
By their numbers in this assay, from the lowest: compounds 4, 3 and 1 (each within the scatter of the next); then compound 2.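

In this assay the change to 5-(trifluoromethyl)pyridin-2-yl on the sulfur gives a number 1.2 percentage points lower from compound 1 to compound 4 (within the scatter) and so does not separate the two compounds on the core of compound 1. Among these compounds, this is the first step at this position on that core, and neither compound reaches the reading of compound 2 at 40.7% on its different core. Nothing available bears on the cause of this result.

Open, on these data alone, is whether 4-ethylphenyl on the sulfur would raise the reading on the core of compound 1. Also open, as far as these compounds go, is whether a group on the sulfur carrying an amine or a carboxylic acid would separate from compound 1.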